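Replacing a Carboxylic Acid by a Methylamide

The source may hold more compounds than are shown below. What is called first, only, known or untested is meant among the compounds shown, and "the series" means these compounds.

Of the compounds shown here, three have been tested in a functional assay on HCT-116 cells (Homo sapiens) for inhibition, read by MTT assay, with a stated time of 72 h; a higher number here means a weaker inhibitor of growth, a lower number a stronger inhibitor of growth. Compound 1 `CNC(=O)/C=C/c1ccncc1-c1ccc2ccccc2c1` gives 6550 nM in this assay. Compound 2 `O=C(O)/C=C/c1ccncc1-c1ccc2ccccc2c1` carries a carboxy group where compound 1 carries a methylcarbamoyl group; in this assay compound 2 reaches only a limit of the assay, > 30000 nM. Compound 3 `Cn1ccc2cc(-c3cnccc3/C=C/C(=O)O)ccc21` is built on a different core and gives 7260 nM in this assay; the difference between the core of compound 2 and the core of compound 3 is not broken down here.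

One change occurs twice among these compounds. From compound 2 to compound 1 it is methylamino in place of hydroxy on a carbonyl carbon and the step it made is an at least 4.5-fold lower number from compound 2 to compound 1 (0.66 log units; beyond the scatter). Because one of the three values sits at the limit of > 30000 nM in this assay, at which 1 of the 3 values shown sits, the size of that step is known only as a floor, not as a full number.

The same change, (methylamino in place of hydroxy on a carbonyl carbon), leads from compound 3 to compound 4 `CNC(=O)/C=C/c1ccncc1-c1ccc2c(ccn2C)c1`, which has not yet been measured. The surroundings of the place are described in the same words in both cases, so it is the same change, not merely the same kind. On these data alone, the value of compound 4 in this assay is expected to be lower than that of compound 3, resting on the earlier step of an at least 4.5-fold lower number from compound 2 to compound 1 (0.66 log units; beyond the scatter), though that step carried a compound from a limit into the measurable range, so its full size is unknown. The step expected here is a 3.6-fold lower number from compound 3 to compound 4 (0.56 log units; beyond the scatter). In this assay compound 4 is estimated at 2000 nM, with a range from 600 nM to 6000 nM.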

Compound 4, concentration for 50% growth inhibition: 4450 nM
Estimate against measurement, compound 4: 2.2-fold (0.35 log units) below, within the range that was stated.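

In this assay, the change from carboxy to methylcarbamoyl gives a 1.6-fold lower number from compound 3 to compound 4 (0.21 log units; within the scatter), so on this core the change does not clearly move the number at all. Set beside the earlier pair, the same change does not carry over from one core to the other at the same size: the same change on two cores in this assay, an at least 4.5-fold lower number (0.66 log units; beyond the scatter) from compound 2 to compound 1 and a 1.6-fold lower number (0.21 log units; within the scatter) from compound 3 to compound 4, at least 2.8-fold (0.44 log units) apart, beyond the scatter of two such steps. This does not show how large the earlier step really is, nor how far the two steps truly lie apart, since compound 2 stands at a limit of the assay and both sizes are therefore floors: the limit of > 30000 nM in this assay, at which 1 of the 4 values shown sits.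

For the compounds shown here, with only two cores, it remains open whether the step on a third core would look like the larger one, the smaller one, or neither, and nothing here explains why the two cores differ. On these data alone, it also remains open how other groups on the same carbonyl carbon would behave on either core, for example a dimethylamino group, an ethylamino group with its longer chain, or a plain amino group, and whether any of them would give a step beyond the scatter on the core of compound 3.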